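Replacing the ester chain with a phenethyl thioester

This account rests on a few compounds, and the source may have more. Where it says the series, first, only, none or still open, it means among the compounds named here.

Going by the values given here, compound 1 `CCCCCCCCOC(=O)NC(=O)Oc1c(C(C)C)cccc1C(C)C` gives 250 nM in an assay on microsomes from intestine for inhibition of acyl-CoA:cholesterol acyltransferase (Oryctolagus cuniculus) (on this read-out lower numbers stand for stronger inhibition and higher numbers for weaker inhibition), the second highest of the three numbers so far. Compound 3 `CCCCCCCC(C)OC(=O)NC(=O)Oc1c(C(C)C)cccc1C(C)C` gives 97 nM, and compound 2 `CCCCCCCCCCCCCCCCCCOC(=O)NC(=O)Oc1c(C(C)C)cccc1C(C)C` gives 1000 nM. Compound 4 `CC(C)c1cccc(C(C)C)c1OC(=O)NC(=O)SCCc1ccccc1` carries phenethylsulfanyl in place of octyloxy on a carbonyl carbon. Both known steps alter the same ester chain: a 4.0-fold higher number from compound 1 to compound 2 (0.60 log units; beyond the scatter) and a 2.6-fold lower number from compound 1 to compound 3 (0.41 log units; beyond the scatter). Neither step involves a sulfur or an aromatic ring, so they bear only loosely on compound 4, yet both show that changes to this chain shift this assay by modest amounts in either direction. A small step is therefore expected, a 1.3-fold lower number from compound 1 to compound 4 (0.10 log units; within the scatter), without a firm direction. Compound 4 is estimated at 200 nM, within 60 nM to 700 nM.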

Compound 4, half-maximal inhibitory concentration: 880 nM
Compound 4: middle estimate off by 4.4-fold (0.64 log units), on the low side; measured number above the stated range.
By their numbers in this assay, from the lowest: compound 3; then compound 1; then compounds 4 and 2 (each within the scatter of the next).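

With phenethylsulfanyl in place of octyloxy on a carbonyl carbon, this assay shows a 3.5-fold higher number from compound 1 to compound 4 (0.55 log units; beyond the scatter), so inhibition weakens beyond the scatter although the heavy-atom count stays the same. Unlike the earlier steps, this change replaces the oxygen with sulfur and brings in an aromatic ring, and the single step cannot separate the two. No available evidence accounts for the weaker inhibition. Still open, from the compounds shown here alone, is how octylsulfanyl, which keeps the sulfur without the ring, and phenethyloxy, which keeps the ring without the sulfur, would each compare with compound 1 in this assay.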